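The source may hold more compounds than are shown below. What is called first, only, known or untested is meant among the compounds shown, and "the series" means these compounds.

For the measured compounds named here, compound 2 `NS(=O)(=O)OC[C@@H]1C[C@@H](n2nnc3c(NCCCc4ccccc4)ncnc32)C[C@@H]1O` gives 149 nM in an assay on a protein complex for inhibition of NEDD8 activating enzyme (Homo sapiens), read by HTRF, with a stated time of 2 h, in the presence of a further agent that is not named here (on this read-out lower numbers stand for stronger inhibition and higher numbers for weaker inhibition), and holds the only number so far. Compound 1 `NS(=O)(=O)OC[C@@H]1C[C@@H](n2ncc3c(N[C@H]4CCc5ccccc54)ccnc32)C[C@@H]1O` returns a limit, > 10000 nM, in this assay; this is the limit of > 10000 nM in this assay, at which 1 of the 2 values shown sits. Compound 3 `COC(=O)[C@H]1C=C[C@@H](Nc2ncnc3c2nnn3[C@@H]2C[C@@H](COS(N)(=O)=O)[C@@H](O)C2)C1` is not yet measured. It differs from compound 2 by a group of 9 heavy atoms (7 carbon, 2 oxygen; one five-membered non-aromatic ring of carbon only) in place of a group of 9 heavy atoms (9 carbon; one six-membered aromatic ring of carbon only), on a nitrogen on an aromatic ring. Going by the values given here, no measured step covers a change of this kind, so the direction is open; a moderate loss beyond the scatter is expected, with the step estimated as a 3.0-fold higher number from compound 2 to compound 3 (0.48 log units; beyond the scatter). Compound 3 is expected to give 450 nM in this assay, in the range 80 nM to 3000 nM.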

Compound 3, half-maximal inhibitory concentration: 80.9 nM
The estimate for compound 3 lay 5.6-fold (0.75 log units) above the measured number, within the range that was stated.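

Replacing 3-phenylpropyl on the nitrogen with the group built on a five-membered non-aromatic ring of carbon only gives a 1.8-fold lower number from compound 2 to compound 3 (0.27 log units; within the scatter). At this place, then, a six-membered aromatic ring of carbon only is not needed to keep the value at this level, and two quite different groups read alike. No evidence here bears on a cause for this step.

Going by these compounds, it remains open whether the methyl ester contributes, which a carboxylic acid or a primary amide on the same ring would test. On these data alone, the role of the two defined stereocentres also remains open.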